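The compounds below may be only part of what the source reports. "The series", "measured", "known", "first", "only" and "open" are said of these compounds alone.

Compound 1 `CSc1nc(SC)c2ncn([C@@H]3C[C@@H](O)[C@H](CO)O3)c2n1` measured in a functional assay on Raji cells (Homo sapiens) (a lower number here means a stronger inhibitor, a higher number a weaker inhibitor), gives 170 uM.
Compound 2 `CN(C)c1nc(Br)nc2c1ncn2[C@@H]1C[C@@H](O)[C@H](CO)O1` returns only a limit in this assay, namely > 300 uM.

Among the two results in this assay, compound 1 stands as the only actual number; the other result is the limit of > 300 uM in this assay, at which 1 of the 2 values shown sits, so no measured step between two numbers exists from which the weight of any structural change could be read.

The compound not yet measured is compound 3 `CSc1nc(N)c2ncn([C@@H]3C[C@@H](O)[C@H](CO)O3)c2n1`. It differs from compound 1 in a single place: amino in place of methylsulfanyl on an aromatic carbon. Within the data shown here, no pair of measured compounds differing in one place is available, so the size of this step in this assay rests on no precedent from these data. With nothing pointing either way, the step from compound 1 to compound 3 is expected to stay within the usual scatter, as an estimate of a 1.1-fold lower number from compound 1 to compound 3 (0.05 log units; within the scatter). Compound 3 is therefore expected to give about 150 uM in this assay, in a range from 40 uM to 400 uM, with a real chance that the assay reports only a limit.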

Compound 3, concentration for 50% inhibition: 107 uM
Compound 3: the middle estimate sits 1.4-fold (0.15 log units) above what was measured, within the range that was stated.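

In this assay, among these compounds, this is the first measured step at this position: a 1.6-fold lower number from compound 1 to compound 3 (0.20 log units; within the scatter). It shows that on this aromatic carbon, next to the ring nitrogen, amino with 1 hydrogen-bond donor can take the place of methylsulfanyl with 0 hydrogen-bond donors, and that the swap from 2 heavy atoms to 1 leaves a measurable value that stays within the scatter of compound 1. Nothing measured here accounts for the size of this step, which is small in any case, and no other pair of compounds offers a step to set beside it.

Among the compounds shown here, compound 2 differs from compound 1 and compound 3 in more than one place, and its result is only a limit, so it adds no second step: the limit of > 300 uM in this assay, at which 1 of the 3 values shown sits. As far as these compounds go, it stays open whether a carboxylic acid, a hydroxyl group or a longer alkylsulfanyl chain on this carbon would move the number beyond the scatter, and whether the methylsulfanyl group that compound 3 keeps on the core would tolerate the same swap to amino.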